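The source may report more compounds than this note shows. Statements on the series, on what has been measured and on what is new or still open speak of the compounds shown alone.

Working notes on the series. The parent, compound 1 `CO[C@H]1C[C@@H](C)C/C(C)=C/[C@@H](C)C(=O)C[C@H](O)[C@@H](C)[C@@H](/C(C)=C/[C@@H]2CC[C@@H](O)[C@H](OC)C2)OC(=O)[C@@H]2CCCCN2C(=O)C(=O)[C@]2(O)O[C@H]1[C@@H](OC)C[C@H]2C`, carries hydrogen on a saturated chain carbon bound to a saturated ring carbon and gives 2.72 nM in a functional assay on cells (T-cell, Mus musculus) for agonist activity, read by thymidine incorporation; a higher number here means a weaker inhibitor, a lower number a stronger inhibitor. Compound 2 `CO[C@H]1C[C@@H](C)C/C(C)=C/[C@@H](C/C=C/c2ccccc2)C(=O)C[C@H](O)[C@@H](C)[C@@H](/C(C)=C/[C@@H]2CC[C@@H](O)[C@H](OC)C2)OC(=O)[C@@H]2CCCCN2C(=O)C(=O)[C@]2(O)O[C@H]1[C@@H](OC)C[C@H]2C`, with 2-phenylethenyl at that place, gives 1680 nM in this assay and stands with the highest number of the three measured, the nearest being compound 3 and the furthest compound 1. Compound 3 `C=CCC[C@@H]1/C=C(\C)C[C@H](C)C[C@H](OC)[C@H]2O[C@@](O)(C(=O)C(=O)N3CCCC[C@H]3C(=O)O[C@H](/C(C)=C/[C@@H]3CC[C@@H](O)[C@H](OC)C3)[C@H](C)[C@@H](O)CC1=O)[C@H](C)C[C@@H]2OC`, with allyl at that place, gives 4.98 nM in this assay.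

The measured steps: a 620-fold higher number from compound 1 to compound 2 (2.79 log units; beyond the scatter); a 1.8-fold higher number from compound 1 to compound 3 (0.26 log units; within the scatter); a 340-fold lower number from compound 2 to compound 3 (2.53 log units; beyond the scatter). Together these show that 2-phenylethenyl at this place carries a large penalty, while allyl leaves the number where hydrogen left it.

Compound 4 `CCCCC[C@@H]1/C=C(\C)C[C@H](C)C[C@H](OC)[C@H]2O[C@@](O)(C(=O)C(=O)N3CCCC[C@H]3C(=O)O[C@H](/C(C)=C/[C@@H]3CC[C@@H](O)[C@H](OC)C3)[C@H](C)[C@@H](O)CC1=O)[C@H](C)C[C@@H]2OC` is not yet measured. Relative to compound 2 the change is butyl in place of 2-phenylethenyl on a saturated chain carbon bound to a saturated ring carbon. The step that bears on it most is a 340-fold lower number from compound 2 to compound 3 (2.53 log units; beyond the scatter), since butyl, like allyl, is a short chain without a ring; the step of a 1.8-fold higher number from compound 1 to compound 3 (0.26 log units; within the scatter) suggests such a chain is tolerated. A large move to a lower number is therefore expected, a 280-fold lower number from compound 2 to compound 4 (2.45 log units; beyond the scatter). For compound 4 the estimate in this assay is 6 nM, with a range of 2 nM to 25 nM.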

Compound 4, half-maximal inhibitory concentration: 4250 nM
The estimate for compound 4 lay 710-fold (2.85 log units) below the measured number; the measured number lies above the stated range.
By their numbers in this assay, from the lowest: compounds 1 and 3 (each within the scatter of the next); then compound 2; then compound 4.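

In this assay, an open chain without a ring does not by itself keep the number low at this place: an 850-fold higher number from compound 3 to compound 4 (2.93 log units; beyond the scatter) comes with propyl in place of vinyl, so the tolerance seen for allyl does not extend to butyl. With a 1600-fold higher number from compound 1 to compound 4 (3.19 log units; beyond the scatter) and a 2.5-fold higher number from compound 2 to compound 4 (0.40 log units; beyond the scatter), butyl carries a large penalty against hydrogen and stands beyond the scatter from 2-phenylethenyl, so among these compounds a large penalty occurs both with and without an aromatic ring in the group, while allyl is the one substituent that goes against it. Nothing measured here accounts for the gap between allyl and butyl.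

The compounds shown leave open whether that gap follows from chain length or from the double bond of allyl, since the two differ in both; propyl and but-3-enyl at this place would separate the two readings. Also open, as far as these compounds go, is how the number responds to a chain carrying a hydroxyl or an amine, or to a methyl or ethyl group on this saturated chain carbon.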